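The source may hold more compounds than are shown below. What is called first, only, known or untested is meant among the compounds shown, and "the series" means these compounds.

Compound 1 has the structure `COC(=O)[C@@]1(C)CCC=C2[C@@H]1CC[C@@H](C)[C@]2(C)Cc1c[nH]c2ccccc12`. In a functional assay on WiDr cells (Homo sapiens) for inhibition, read by sulforhodamine B assay, with a stated time of 48 h (a lower number here means a stronger inhibitor of growth, a higher number a weaker inhibitor of growth), compound 1 gives 8700 nM. Compound 2, with the structure `COC(=O)[C@@]1(C)CCC=C2[C@@H]1CC[C@@H](C)[C@]2(C)Cc1c[nH]c2ccc(C)cc12`, differs from compound 1 in one place, described as methyl in place of hydrogen on an aromatic carbon; in this assay compound 2 gives 22000 nM, and the step of a 2.5-fold higher number from compound 1 to compound 2 (0.40 log units; beyond the scatter) is beyond the usual scatter.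

Compound 3, with the structure `COC(=O)[C@@]1(C)CC[C@@H]2C3=C1CC[C@@H](C)[C@]3(C)C[C@@H]1c3ccccc3N[C@H]21`, is built from the same atoms as compound 1, joined differently; the difference between the two cores is not broken down here. In this assay compound 3 gives 50000 nM, the highest of the three numbers.

Compound 4, with the structure `COC(=O)[C@@]1(C)CC[C@@H]2C3=C1CC[C@@H](C)[C@]3(C)C[C@@H]1c3cccc(C)c3N[C@H]21`, has not been measured. It differs from compound 3 by methyl in place of hydrogen on an aromatic carbon. This is the same kind of change as that from compound 1 to compound 2, but the place is not the same: in compound 2 the methyl sits meta and para to a fused ring on a two-ring system, whereas in compound 4 it sits ortho and meta to a fused ring on a five-ring system.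

Because compound 1 to compound 2 showed a 2.5-fold higher number from compound 1 to compound 2 (0.40 log units; beyond the scatter), a step of similar size is expected from compound 3 to compound 4, namely a 2.0-fold higher number from compound 3 to compound 4 (0.30 log units; within the scatter), with wide uncertainty since the starting point is already weak. Compound 4 is thus estimated to give 100000 nM in this assay, plausibly between 40000 nM and 250000 nM.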

Compound 4, concentration for 50% growth inhibition: 43000 nM
Compound 4: middle estimate off by 2.3-fold (0.37 log units), on the high side; measured number inside the range.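

In this assay, a methyl in place of hydrogen on an aromatic carbon of the system of five rings gives a 1.2-fold lower number from compound 3 to compound 4 (0.07 log units; within the scatter), so this step stays inside the usual scatter and the two numbers cannot be told apart. The same kind of change on the core of compound 1 gave a step beyond the scatter, and the two steps differ by more than such a pair of steps would by chance: the same change on two cores in this assay, a 2.5-fold higher number (0.40 log units; beyond the scatter) from compound 1 to compound 2 and a 1.2-fold lower number (0.07 log units; within the scatter) from compound 3 to compound 4, 2.9-fold (0.47 log units) apart, beyond the scatter of two such steps This shows that the size of the step seen on one core did not carry over to the other in this series, but it does not show why, since the methyl sits in a different place on a different core and a single pair on each core cannot separate those two differences.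

The compounds shown leave open whether a methyl on another aromatic carbon of the core of compound 3 would give a step closer to the one on the core of compound 1. They also leave open how a chlorine atom or a methoxy group on these aromatic carbons, or a carboxylic acid in place of the methyl ester, would read on either core.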